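This account rests on a few compounds, and the source may have more. Where it says the series, first, only, none or still open, it means among the compounds named here.

Measured so far in an assay on isolated protein for inhibition of protein kinase C zeta type (Homo sapiens), with a stated time of 4 min, tested at 62.5 uM; a lower number here means less inhibition, a higher number more inhibition at the concentration tested (going by the name of the read-out):
compound 1, `CC(C)(C)C1=NN(c2cccc(F)c2)C(c2ccc(O)cc2)C1`, gives 98.1%
compound 2, `Cc1cccc(N2N=C(C(C)(C)C)CC2c2ccc(O)cc2)c1`, gives 91.7%
compound 3, `CC(C)(C)C1=NN(c2ccccc2Cl)C(c2ccc(O)cc2)C1`, gives 57.1%

Compound 3 stands lowest of the three numbers in this assay. Compound 2 is nearest to it and compound 1 furthest, and both gaps lie beyond the scatter. The two steps that lead into compound 3 are large: a number 41 percentage points lower from compound 1 to compound 3 (beyond the scatter) and a number 34.6 percentage points lower from compound 2 to compound 3 (beyond the scatter). The step of a number 6.4 percentage points lower from compound 1 to compound 2 (within the scatter), by contrast, is within the scatter.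

Compound 4 is `CC(C)(C)C1=NN(c2ccccc2F)C(c2ccc(O)cc2)C1`. It differs from compound 3 in one place: fluoro in place of chloro on an aromatic carbon. Among the compounds with values here, no measured pair shows fluoro in place of chloro on an aromatic carbon, and no measured pair alters a group that sits ortho to a large group. Within the data shown here, the only steps that bear on compound 4 are the two large ones into compound 3, and they concern a change of the whole aryl group on the ring nitrogen, so they fix compound 3 low relative to the others without saying how a halogen swap at the same place would act. The step of a number 7.9 percentage points higher from compound 3 to compound 4 (within the scatter) is therefore expected to be modest and of uncertain direction, leaning slightly upward. For compound 4 the estimate in this assay is 65%, with a range from 40% to 88%.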

Compound 4, a percentage reported as inhibition, at one concentration (the size of the read-out at that concentration, not a potency): 57.6%
The estimate for compound 4 lay 7.4 percentage points above the measured number, and the stated range covers the measured number.
By their numbers in this assay, from the lowest: compounds 3 and 4 (each within the scatter of the next); then compounds 2 and 1 (each within the scatter of the next).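

In this assay the exchange of halogen on this aryl group, ortho to a large group, leaves the number within the scatter (the step is a number 0.5 percentage points higher from compound 3 to compound 4 (within the scatter)), so 2-fluorophenyl and 2-chlorophenyl cannot be told apart here. The low level of compound 3 is therefore not specific to chloro: compound 4 also stands clearly under the two other compounds, as seen in the steps (a number 34.1 percentage points lower from compound 2 to compound 4 (beyond the scatter)) and (a number 40.5 percentage points lower from compound 1 to compound 4 (beyond the scatter)), and among these four compounds none goes against this grouping. The last of these steps is the most telling comparison, as 2-fluorophenyl and 3-fluorophenyl carry the same halogen and differ only in its place on the aryl ring, and the number still falls beyond the scatter.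

A 2-methylphenyl group or a 2-methoxyphenyl group on the ring nitrogen would show whether the low level extends beyond the two halogens, and an unsubstituted phenyl group would provide the missing reference for all of these aryl groups. Nothing available gives a reason for the match between the two halogens or for the drop relative to compound 1 and compound 2.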